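Changing the Aryl Group on the Triazole Nitrogen

The source may hold more compounds than are shown below. What is called first, only, known or untested is meant among the compounds shown, and "the series" means these compounds.

Of the compounds shown here, three built on one shared core have been tested in a functional assay on A549 cells (Homo sapiens) for inhibition, read by sulforhodamine B assay, with a stated time of 48 h, tested at 50 uM; a lower number here means less inhibition of growth, a higher number more inhibition of growth at the concentration tested. Compound 1 `COc1ccc([C@@H]2C/C(=N/OCc3cn(-c4ccc(Cl)cc4C)nn3)c3cc(CC=C(C)C)c(OC)cc3O2)cc1` gives 35%. Compound 2 `COc1ccc([C@@H]2C/C(=N/OCc3cn(-c4ccccc4CO)nn3)c3cc(CC=C(C)C)c(OC)cc3O2)cc1` gives 100%, and compound 3 `COc1ccc([C@@H]2C/C(=N/OCc3cn(-c4ccc(C(N)=O)cc4)nn3)c3cc(CC=C(C)C)c(OC)cc3O2)cc1` gives 100%. The step of a number 65 percentage points higher from compound 1 to compound 2 (beyond the scatter) and the step of a number 65 percentage points higher from compound 1 to compound 3 (beyond the scatter) were both large, while the step of no change at the digits printed from compound 2 to compound 3 (within the scatter) showed no movement. Compound 3 therefore stands level with compound 2 at the top of the three numbers, far above compound 1.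

Compound 4 `COc1ccc([C@@H]2C/C(=N/OCc3cn(-c4cccnc4Cl)nn3)c3cc(CC=C(C)C)c(OC)cc3O2)cc1` differs from compound 3 in one place: 2-chloropyridin-3-yl in place of 4-carbamoylphenyl on an aromatic nitrogen. For the measured compounds named here, two measured steps bear on this change. The step of no change at the digits printed from compound 2 to compound 3 (within the scatter) shows that exchanging one phenyl group carrying a hydrogen-bond donor for another made no difference, whereas the step of a number 65 percentage points higher from compound 1 to compound 3 (beyond the scatter) shows a large gain when a chlorine-bearing group without a donor was replaced by the carbamoyl group. The entering group of compound 4 carries chlorine and no hydrogen-bond donor, so a downward step a number 45 percentage points lower from compound 3 to compound 4 (beyond the scatter) is expected. Compound 4 is estimated at 55%, within a range from 25% to 95%.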

Compound 4, percent growth inhibition at one concentration: 58%
Compound 4: the middle estimate sits 3 percentage points below what was measured; low and high end bracket the measured number.
By their numbers in this assay, from the lowest: compound 1; then compound 4; then compounds 2 and 3 (each within the scatter of the next).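

The change to 2-chloropyridin-3-yl on the aromatic nitrogen gives a number 42 percentage points lower from compound 3 to compound 4 (beyond the scatter) and a number 42 percentage points lower from compound 2 to compound 4 (beyond the scatter), both large, but also a number 23 percentage points higher from compound 1 to compound 4 (beyond the scatter), a modest step, so this group lands between the earlier extremes. The chlorine-bearing groups of compound 1 and compound 4 give clearly different numbers, which shows that the presence of chlorine alone does not set the level at this position. Nothing available explains why these groups differ in this way.

An unsubstituted pyridin-3-yl group and a 2-chlorophenyl group are not among the compounds shown, so the parts played by the chlorine and the ring nitrogen in compound 4 remain unseparated. Also open, on these data alone, is how a phenyl group carrying an amine or a carboxylic acid compares with the 4-carbamoylphenyl group of compound 3.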